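Chloro for Fluoro, Tried Once and Now Once More

The source may hold more compounds than are shown below. What is called first, only, known or untested is meant among the compounds shown, and "the series" means these compounds.

Compound 1 `O/N=C(/Nc1ccc(F)c(F)c1)c1ccc2occc2c1`: 14000 nM
Compound 2 `O/N=C(/Nc1ccc(F)c(Cl)c1)c1ccc2occc2c1`: 1800 nM
Compound 3 `OCc1cc2cc(/C(=N\O)Nc3cccc(F)c3)ccc2o1`: 2400 nM

All three were tested in an assay on tissue (HeLa cells) for inhibition of Indoleamine 2,3-dioxygenase 1 (Homo sapiens), read by spectrophotometry; on this read-out lower numbers stand for stronger inhibition and higher numbers for weaker inhibition. Going by the values given here, the single change from compound 1 to compound 2 is chloro in place of fluoro on an aromatic carbon, and it brought a 7.8-fold lower number from compound 1 to compound 2 (0.89 log units; beyond the scatter). Compound 3 carries a different core from compound 1; the difference between the two cores is not broken down here. In this assay, among the compounds with values here, compound 3 gives 2400 nM, and that number and the one of compound 2 lie within the usual scatter of each other, so nothing can be said about which of the two is stronger.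

Compound 4 `OCc1cc2cc(/C(=N\O)Nc3cccc(Cl)c3)ccc2o1` has not been measured. It differs from compound 3 by chloro in place of fluoro on an aromatic carbon. Within the data shown here, this is the same kind of change as the one from compound 1 to compound 2, not the same change: in the earlier pair the aromatic carbon is also ortho to a fluoro group (1 heavy atom), whereas in compound 3 and compound 4 it is not.

The step from compound 3 to compound 4 is expected to be a 3.4-fold lower number from compound 3 to compound 4 (0.54 log units; beyond the scatter), somewhat smaller than the earlier one because a 7.8-fold lower number from compound 1 to compound 2 (0.89 log units; beyond the scatter) was measured at a place with a different surrounding, and a single example gives no firm guide. Compound 4 is estimated at 700 nM, with a likely range from 200 nM to 2400 nM.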

Compound 4, half-maximal inhibitory concentration: 5900 nM
Compound 4: the middle estimate sits 8.4-fold (0.93 log units) below what was measured; measured number outside the range, above it.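

In this assay, putting chloro in place of fluoro on the core of compound 3 gave a 2.5-fold higher number from compound 3 to compound 4 (0.39 log units; beyond the scatter), the opposite direction to the earlier result on the core of compound 1. Set side by side, the same change moved the number down on one core and up on the other, and the gap between the two steps is larger than chance scatter would explain: the same change on two cores in this assay, a 7.8-fold lower number (0.89 log units; beyond the scatter) from compound 1 to compound 2 and a 2.5-fold higher number (0.39 log units; beyond the scatter) from compound 3 to compound 4, 19-fold (1.28 log units) apart, beyond the scatter of two such steps. This shows that the gain seen with chloro on the core of compound 1 cannot be assumed to carry over to another core in this series, but it does not show why, since the two pairs differ in their cores and also in the extra fluoro group that compound 1 and compound 2 carry on the ring bearing the change, and two examples cannot separate these differences.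

The compounds shown leave open whether the reversal follows the core or that extra fluoro group, a question that a matched pair with only one of these differences could help settle. They also leave open how other groups at the same place, such as bromo, methyl or methoxy, would behave on either core.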